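Swapping the amide substituent: from 4-methylbenzyl to phenyl

This account rests on a few compounds, and the source may have more. Where it says the series, first, only, none or still open, it means among the compounds named here.

Of the compounds shown here, three built on a shared core have been tested in a functional assay on QGY7701 cells (Homo sapiens) for cytotoxicity, read by MTT assay, with a stated time of 24 h; a higher number here means a weaker inhibitor, a lower number a stronger inhibitor. Compound 1 `C=CC1=C(C(=O)NC2CCCCC2)C(c2ccc(OC)c(OC)c2)OC1` gives 7490 nM. Compound 2 `C=CC1=C(C(=O)NCc2ccc(C)cc2)C(c2ccc(OC)c(OC)c2)OC1` gives 69100 nM, the highest of the three numbers; compound 3 `C=CC1=C(C(=O)NCc2ccc(C)cc2)C(c2ccc(OC)cc2)OC1` gives 43100 nM. Among the compounds with values here, the only step beyond the scatter is a 9.2-fold higher number from compound 1 to compound 2 (0.96 log units; beyond the scatter), while a 1.6-fold lower number from compound 2 to compound 3 (0.21 log units; within the scatter) changes nothing that can be trusted.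

Compound 4 `C=CC1=C(C(=O)Nc2ccccc2)C(c2ccc(OC)c(OC)c2)OC1` has not yet been measured in this assay. It differs from compound 2 by phenyl in place of 4-methylbenzyl on an amide-type nitrogen. Within the data shown here, no measured pair shows exactly this change. The step that bears on it most is a 9.2-fold higher number from compound 1 to compound 2 (0.96 log units; beyond the scatter). It alters the same position: there, a ring attached directly to the amide nitrogen, compared with a 4-methylbenzyl group, went with a far lower number. The step of a 1.6-fold lower number from compound 2 to compound 3 (0.21 log units; within the scatter) lies elsewhere and carries little information here.

On that basis, compound 4 is expected to show a lower number than compound 2, a step estimated as a 3.5-fold lower number from compound 2 to compound 4 (0.54 log units; beyond the scatter). The estimate for compound 4 is 20000 nM, with a plausible range from 6000 nM to 70000 nM.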

Compound 4, half-maximal inhibitory concentration: > 100000 nM
Compound 4 gave a limit, no number; the forecaster's own chance of this, stated with the estimate: 10%; middle value at least 5.0-fold (0.69 log units) away from the limit.
By their numbers in this assay, from the lowest: compound 1; then compounds 3 and 2 (each within the scatter of the next). At a limit, above all of these: compound 4.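

In this assay a ring bonded directly to the amide nitrogen does not by itself give a low number: an at least 13-fold higher number from compound 1 to compound 4 (1.12 log units; beyond the scatter) comes with phenyl in place of cyclohexyl, which shows that the kind of ring at this position matters, not only its direct attachment. Phenyl in place of 4-methylbenzyl gives an at least 1.4-fold higher number from compound 2 to compound 4 (0.16 log units; that floor lies within the scatter) and therefore no firm order for this pair. Compound 4 stands at a limit of the assay, not at a number: the limit of > 100000 nM in this assay, at which 1 of the 4 values shown sits.

As far as these compounds go, how cyclopentyl or a straight hexyl chain on the amide nitrogen would compare with cyclohexyl remains open. From the compounds shown here alone, the true value of compound 4 also remains open, and with it the real distance from the other compounds.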